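Swapping chloro for methoxy on the outer ring

The compounds below may be only part of what the source reports. "The series", "measured", "known", "first", "only" and "open" are said of these compounds alone.

Of the compounds shown here, three sharing one core have been tested in a functional assay on A549 cells (Homo sapiens) for antiproliferative activity, read by MTT assay, with a stated time of 72 h; on this read-out higher numbers stand for weaker inhibition and lower numbers for stronger inhibition. Compound 1 `COc1ccc(-n2c(=O)c(C(=O)Nc3ccc(Oc4ccnc5[nH]ccc45)cc3)cc3cccnc32)cc1` gives 930 nM. Compound 2 `O=C(Nc1ccc(Oc2ccnc3[nH]ccc23)c(F)c1)c1cc2cccnc2n(-c2ccccc2)c1=O` gives 190 nM. Compound 3 `O=C(Nc1ccc(Oc2ccnc3[nH]ccc23)c(F)c1)c1cc2cccnc2n(-c2ccc(Cl)cc2)c1=O` gives 110 nM. On these numbers compound 3 stands lowest of the three, although the gap to compound 2 lies within the scatter; only compound 1 sits clearly apart from it.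

For the measured compounds named here, the one step between neighbours that has been measured is a 1.7-fold lower number from compound 2 to compound 3 (0.24 log units; within the scatter), which shows that putting chloro onto that outer ring changed little.

Compound 4 `COc1ccc(-n2c(=O)c(C(=O)Nc3ccc(Oc4ccnc5[nH]ccc45)c(F)c3)cc3cccnc32)cc1` is compound 3 with a different group on the same aromatic carbon: methoxy in place of chloro on an aromatic carbon, a position the data describe as para to a large group. Going by the values given here, no measured step covers methoxy directly. Compound 1 carries the same methoxy group but lacks the fluoro present in compounds 2, 3 and 4, so its higher number cannot be read as the effect of methoxy alone; it only hints that methoxy may not help. Taking the measured chloro step as small and the methoxy hint as weakly unfavourable, compound 4 is expected to come out at 250 nM, within a range of 100 nM to 700 nM, an estimated 2.3-fold higher number from compound 3 to compound 4 (0.36 log units; beyond the scatter) in this assay.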

Compound 4, half-maximal inhibitory concentration: 610 nM
For compound 4 the middle estimate is 2.4-fold (0.39 log units) below the measured one; low and high end bracket the measured number.
By their numbers in this assay, from the lowest: compounds 3 and 2 (each within the scatter of the next); then compounds 4 and 1 (each within the scatter of the next).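

In this assay this aromatic carbon, para to a large group, turns out to be sensitive to what sits on it: the 4-chlorophenyl to 4-methoxyphenyl change gives a 5.5-fold higher number from compound 3 to compound 4 (0.74 log units; beyond the scatter) and is beyond the scatter, and methoxy in place of hydrogen gives a 3.2-fold higher number from compound 2 to compound 4 (0.51 log units; beyond the scatter) and is also beyond it, whereas the earlier chloro step alone had shown only a change within the scatter. The fluoro comparison, which could only be guessed at before, now has its own step in a 1.5-fold lower number from compound 1 to compound 4 (0.18 log units; within the scatter) and lies within the scatter, so with methoxy on the outer ring the fluoro makes no clear difference, and the methoxy compounds 1 and 4 both sit apart from compound 3. Nothing measured here explains why methoxy gives the higher number at this carbon.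

Going by these compounds, only hydrogen, chloro and methoxy appear at this carbon, so it remains open how a different group, such as an amine, a carboxylic acid or a longer ether chain, would behave there. It is also open whether the fluoro would matter as little alongside a 4-chlorophenyl ring, since the compounds shown hold no pair that tests this.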